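Swapping methyl for furan-2-yl in compound 1

This account rests on a few compounds, and the source may have more. Where it says the series, first, only, none or still open, it means among the compounds named here.

Compound 1 `CC[S+]([O-])CCCCN=C=S` and compound 2 `O=[N+]([O-])c1ccc(C[S+]([O-])CCCCN=C=S)cc1` have both been tested so far in an ADME assay on Vero cells (Chlorocebus sabaeus) for cytotoxicity, read by MTT assay, with a stated time of 72 h (a higher number here means a weaker inhibitor, a lower number a stronger inhibitor), and their two numbers differ by more than the usual scatter. Compound 1 gives 7900 nM there, the higher of the two numbers, while compound 2 gives 3360 nM there. Compound 3 `[O-][S+](CCCCN=C=S)Cc1ccco1` still awaits measurement. The change from compound 1 is furan-2-yl in place of methyl on a saturated chain carbon bound to a sulfur and it amounts to furan-2-yl in place of methyl on a saturated chain carbon bound to a sulfur. Among the measured compounds shown here, with compound 2 at 3360 nM as the only guide, a small move toward a lower number is expected in this assay for this change. The estimated move is a 1.6-fold lower number from compound 1 to compound 3 (0.22 log units; within the scatter) and it sits close to the usual scatter. Compound 3 is expected at 4800 nM with 1800 nM to 12000 nM as its estimated range.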

Compound 3, half-maximal inhibitory concentration: 5250 nM
Compound 3: the middle estimate sits 1.1-fold (0.04 log units) below what was measured; the measured number falls inside the stated range.
By their numbers in this assay, from the lowest: compounds 2, 3 and 1 (each within the scatter of the next, the first and the last beyond it).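

In this assay, furan-2-yl in place of methyl on a saturated chain carbon bound to a sulfur gives a 1.5-fold lower number from compound 1 to compound 3 (0.18 log units; within the scatter). This is the first step shown between two compounds that differ in one place, and it shows that an aromatic ring carrying a hydrogen-bond acceptor can enter at this position without a shift beyond the scatter of this measurement. Nothing measured here speaks to the reason for this result.

From the compounds shown here alone, whether an amine or a carboxylic acid on a saturated chain carbon bound to a sulfur would move the number beyond the scatter remains open. Going by these compounds, it is also open whether an unsubstituted phenyl ring there would give a number close to that of compound 3 in this assay.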